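The source may hold more compounds than are shown below. What is called first, only, known or untested is meant among the compounds shown, and "the series" means these compounds.

Measured compounds:
- compound 1, `C=CC(=C)CC[C@@H]1[C@@]2(C)CCC[C@](C)(COC(=O)/C=C/c3ccc(O)cc3)[C@@H]2CC[C@@]1(C)O`: in a functional assay on A549 cells (Homo sapiens) for cytotoxicity, read by MTT assay, with a stated time of 48 h (a higher number here means a weaker inhibitor, a lower number a stronger inhibitor), compound 1 gives 20400 nM
- compound 2, `C=CC(=C)CC[C@@H]1[C@@]2(C)CCC[C@](C)(COC(=O)/C=C/c3ccc(O)c(OC)c3)[C@@H]2CC[C@@]1(C)O`: in this assay compound 2 gives 16800 nM

Among these two numbers compound 2 holds the lower one, but the step of a 1.2-fold lower number from compound 1 to compound 2 (0.08 log units; within the scatter) places the two within the scatter, so neither compound can be called the stronger inhibitor on this evidence. Among the compounds with values here, the only measured step thus concerns a methoxy in place of hydrogen on an aromatic carbon and tells nothing about the geometry of the ester linker.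

Compound 3, `C=CC(=C)CC[C@@H]1[C@@]2(C)CCC[C@](C)(COC(=O)/C=C\c3ccc(O)c(OC)c3)[C@@H]2CC[C@@]1(C)O`, is related to compound 2 as follows: the two compounds have the same atoms and bonds and differ only in configuration as drawn: 1 of 6 stereo elements differ; a double bond is drawn E in compound 2 and Z in compound 3. Within the data shown here, no measured pair in this set changes a double-bond geometry, so the step from compound 2 to compound 3 has no direct precedent here. With nothing to indicate a shift in either direction, the expectation is that compound 3 lands close to compound 2 in this assay, the estimated step being a 1.2-fold higher number from compound 2 to compound 3 (0.08 log units; within the scatter), which stays within the scatter. Compound 3 is therefore estimated at 20000 nM, with a range from 8000 nM to 50000 nM.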

Compound 3, half-maximal inhibitory concentration: 17300 nM
Compound 3: the middle estimate sits 1.2-fold (0.06 log units) above what was measured; the range from low to high includes it.
By their numbers in this assay, from the lowest: compounds 2, 3 and 1 (each within the scatter of the next).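

In this assay, the geometry of the ester double bond now has a measured pair of its own: the step is a 1.0-fold higher number from compound 2 to compound 3 (0.01 log units; within the scatter), so with the methoxy group present, drawing this bond Z rather than E gives no change that can be told from scatter. This pair isolates the double bond, as no other structural feature separates the two compounds: the fact that compounds 2 and 3 differ only in the configuration as drawn. Taking the methoxy group and the Z bond together, the step is a 1.2-fold lower number from compound 1 to compound 3 (0.07 log units; within the scatter), which leaves all three compounds indistinguishable in this assay, so neither change on its own nor the two combined has yet shifted the number.

As far as these compounds go, it remains open whether the Z double bond would read the same on the 2-(4-hydroxyphenyl)ethenyl group, which lacks the methoxy group. From the compounds shown here alone, it is also open whether an amide in place of the ester, or an amine or a carboxylic acid in place of the hydroxy group on the aromatic ring, would move the number beyond the scatter.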